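Methyl to ethyl on compound 3

The source may hold more compounds than are shown below. What is called first, only, known or untested is meant among the compounds shown, and "the series" means these compounds.

In a functional assay on MCF7 cells (Homo sapiens) for antiproliferative activity, with a stated time of 5 days (a higher number here means a weaker inhibitor, a lower number a stronger inhibitor), compound 1 `CCCCc1ccc2[nH]c(-c3ccc(OC)cc3)c(C=C(C#N)C#N)c2c1` gives 13 nM, compound 2 `CCCCCCc1ccc2[nH]c(-c3ccc(OC)cc3)c(C=C(C#N)C#N)c2c1` gives 25 nM and compound 3 `CCCCc1ccc2[nH]c(-c3ccc(C)cc3)c(C=C(C#N)C#N)c2c1` gives 100 nM, the highest number of the three. Compound 4 `CCCCc1ccc2[nH]c(-c3ccc(CC)cc3)c(C=C(C#N)C#N)c2c1` differs from compound 3 by one change: methyl in place of hydrogen on a saturated chain carbon bound to an aromatic carbon. Within the data shown here, two measured steps bear on it. Chain extension elsewhere gave a 1.9-fold higher number from compound 1 to compound 2 (0.28 log units; within the scatter), within the scatter. Methyl in place of methoxy gave a 7.7-fold higher number from compound 1 to compound 3 (0.89 log units; beyond the scatter), beyond the scatter, but that step swaps one group for a different one. No step beyond the scatter is therefore expected in this assay, and no direction is firm. The estimated step is a 1.1-fold higher number from compound 3 to compound 4 (0.04 log units; within the scatter). For compound 4 the estimate is 110 nM, with an expected range of 45 nM to 280 nM.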

Compound 4, half-maximal inhibitory concentration: 200 nM
Compound 4: middle estimate off by 1.8-fold (0.26 log units), on the low side; low and high end bracket the measured number.
By their numbers in this assay, from the lowest: compounds 1 and 2 (each within the scatter of the next); then compounds 3 and 4 (each within the scatter of the next).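

In this assay the methyl to ethyl change on the 4-methylphenyl group gives a 2.0-fold higher number from compound 3 to compound 4 (0.30 log units; within the scatter) and so leaves no measurable difference between these two groups at this place. Ethyl in place of methoxy gives a 15-fold higher number from compound 1 to compound 4 (1.19 log units; beyond the scatter) and joins a 7.7-fold higher number from compound 1 to compound 3 (0.89 log units; beyond the scatter) in showing that neither of these chains reproduces the low number seen with methoxy. The data offer no measured explanation for this. On these data alone, whether ethoxy or an amine at this place would keep the number of compound 1 stays open. So does the effect of a longer chain than ethyl.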